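This account rests on a few compounds, and the source may have more. Where it says the series, first, only, none or still open, it means among the compounds named here.

Working notes on the series in an ADME assay on Vero cells (Chlorocebus sabaeus) for cytotoxicity, read by MTT assay, with a stated time of 24 h; on this read-out lower numbers stand for stronger inhibition and higher numbers for weaker inhibition. Compound 1 (`O=C1c2ccccc2OCC1Cc1ccc(F)cc1`) has no exact number here, only a limit: compound 1 gives > 200000 nM. Compound 2 (`COc1ccc(CC2COc3ccccc3C2=O)c(OC)c1`) is also reported only as a limit, and compound 2 gives > 200000 nM. The evidence so far is thus confined to one line: the limit of > 200000 nM in this assay, at which 2 of the 2 values shown sit. Compound 3 (`Cc1ccc(CC2COc3ccccc3C2=O)cc1`) differs from compound 1 at a single place: methyl in place of fluoro on an aromatic carbon. This is methyl in place of fluoro on an aromatic carbon, para to a large group. Among the measured compounds shown here, no measured step sizes this change. The expected step that the limit leaves unreadable from compound 1 to compound 3 is none beyond the usual scatter, with no direction expected in this assay. Compound 3 is estimated at 220000 nM, with an expected range of 100000 nM to 400000 nM.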

Compound 3, half-maximal inhibitory concentration: > 200000 nM
Compound 3: no number, only a limit; the forecaster's own chance of this, stated with the estimate: 85%; the middle value does not contradict the limit.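

No step can be read from compound 1 to compound 3, since both results are limits and not numbers: the limit of > 200000 nM in this assay, at which 3 of the 3 values shown sit. The compounds shown leave open whether methyl in place of fluoro on an aromatic carbon changes the read-out at all.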